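The compounds below may be only part of what the source reports. "The series", "measured", "known", "first", "only" and "open" are said of these compounds alone.

Measured so far:
compound 1, `COc1cc(/C=C/C(=O)C2=C(/C=C/c3ccc(O)c(OC)c3)NC(=O)NC2c2ccccc2)ccc1O`: 31%
compound 2, `COc1cc(/C=C/C(=O)C2=C(/C=C/c3ccc(O)c(OC)c3)NC(=O)NC2c2cccc([N+](=O)[O-])c2)ccc1O`: 33%

Within the data shown here, in a functional assay, with a stated time of 20 min, tested at 20 uM (on this read-out lower numbers stand for a weaker effect and higher numbers for a stronger effect at the one concentration tested), compound 2 gives the higher of the two numbers, but the single measured step of a number 2 percentage points higher from compound 1 to compound 2 (within the scatter) lies within the scatter, so compound 2 and compound 1 are not separable on this read-out.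

Compound 3, `COc1cc(/C=C/C(=O)C2=C(/C=C/c3ccc(O)c(OC)c3)NC(=O)NC2c2ccccc2Cl)ccc1O`, differs from compound 2 by 2-chlorophenyl in place of 3-nitrophenyl on a saturated ring carbon. Among the measured compounds shown here, the only step that bears on it is a number 2 percentage points higher from compound 1 to compound 2 (within the scatter), which shows that adding the nitro changed nothing beyond the scatter; its loss is therefore expected to matter little, while no measured step speaks to the entering 2-chlorophenyl. No step beyond the scatter is expected in this assay, the expected step being a number 2 percentage points lower from compound 2 to compound 3 (within the scatter). Compound 3 is estimated at 31%, within 16% to 46%.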

Compound 3, a percentage reported as activity, at one concentration (the size of the read-out at that concentration, not a potency): 38.7%
For compound 3 the middle estimate is 7.7 percentage points below the measured one, within the range that was stated.
By their numbers in this assay, from the lowest: compounds 1, 2 and 3 (each within the scatter of the next).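

In this assay, 2-chlorophenyl in place of 3-nitrophenyl on the saturated ring carbon gives a number 5.7 percentage points higher from compound 2 to compound 3 (within the scatter), and chloro in place of hydrogen on the aromatic carbon gives a number 7.7 percentage points higher from compound 1 to compound 3 (within the scatter). This position therefore carries phenyl, 3-nitrophenyl and 2-chlorophenyl without any separation on this read-out, and a chloro substituent joins nitro as a change that stays within the scatter. No supporting measurement bears on this result.

Still open, going by these compounds, is whether an amine or a carboxylic acid on the phenyl ring would give a step beyond the scatter. The same question stands for a longer chain in place of the phenyl ring.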